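A few compounds are considered here, and "the series" means these few. Any claim that something is new, unique, unknown or untested is made for them only; others in the source may bear on it.

Working notes on the series.

Compound 1 `Cc1nc2cc(C(=O)NCc3ccc(F)c(C4CC4)c3)nn2c(-c2cc(F)c3c(c2C)CCCO3)c1[C@H](OC(C)(C)C)C(=O)O` and compound 2 `COc1cc(F)ccc1CNC(=O)c1cc2nc(C)c([C@H](OC(C)(C)C)C(=O)O)c(-c3cc(F)c4c(c3C)CCCO4)n2n1` share the same core and the same amide, and differ only in the benzyl group. In an ADME assay on MT2 cells (Homo sapiens) for cytotoxicity (on this read-out higher numbers stand for lower toxicity in this test and lower numbers for higher toxicity in this test), compound 1 gives > 40000 nM, which is a limit of the assay and not a number. In this assay compound 2 likewise gives > 40000 nM, again a limit rather than a number. Going by the values given here, the one step on record, a step that the two limits leave unreadable from compound 1 to compound 2, is therefore not readable in size or direction. Where compound 2 stands is known only as a limit, and the one further value shown is a limit too; both sit at the limit of > 40000 nM in this assay, at which 2 of the 2 values shown sit.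

Compound 3 `Cc1nc2cc(C(=O)NCc3ccc(F)cc3O)nn2c(-c2cc(F)c3c(c2C)CCCO3)c1[C@H](OC(C)(C)C)C(=O)O` is the next member, differing from compound 2 by hydrogen in place of methyl on an oxygen on an aromatic ring. Among the compounds with values here, no measured step bears on this change, and the step from compound 1 to compound 2 cannot be read, so no shift beyond the scatter is expected in this assay. The step expected from this estimate is a step that the limit leaves unreadable from compound 2 to compound 3. Compound 3 is expected to give 60000 nM, with a range from 25000 nM to 150000 nM, most likely reported once more as a limit.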

Compound 3, half-maximal cytotoxic concentration: > 40000 nM
Compound 3 gave a limit, no number; the forecaster's own chance of this, stated with the estimate: 85%; the middle value is on the limit's open side.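

In this assay compound 3 gives > 40000 nM, a limit and not a number. No step among compound 1, compound 2 and compound 3 can be read in size or direction, and all sit at one value: the limit of > 40000 nM in this assay, at which 3 of the 3 values shown sit.

The compounds shown leave open whether any change in the benzyl group shifts the half-maximal cytotoxic concentration.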